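Hydrazone inhibitors: a pyridinyl in place of chlorophenyl

The source may hold more compounds than are shown below. What is called first, only, known or untested is meant among the compounds shown, and "the series" means these compounds.

Compound 1, `C/C(=N\N(Cc1ccccc1)Cc1ccccc1)c1ccccc1`, gives 25000 nM in an assay on liver (Sus scrofa) for inhibition of glucose-6-phosphatase catalytic subunit 1 (Homo sapiens), using microsomes; a lower number here means a stronger inhibitor, a higher number a weaker inhibitor.
Compound 2, `c1ccc(CN(Cc2ccccc2)/N=C2\CCCc3ccccc32)cc1`, gives 25000 nM in this assay.
Compound 3, `Clc1ccc(/C=N/N(Cc2ccccc2)Cc2ccccc2)cc1`, gives 240 nM in this assay.

Compound 3 holds the lowest number of the three, and the gaps to compound 1 and to compound 2 both lie well beyond the scatter, so it is the strongest inhibitor shown. Compound 4, `C(=N/N(Cc1ccccc1)Cc1ccccc1)\c1cccnc1`, differs from compound 3 by pyridin-3-yl in place of 4-chlorophenyl on a carbon with a double bond to nitrogen. No measured pair among these compounds shows a change of this kind, so the size of the step rests on judgement alone. A moderate move toward a weaker inhibitor is expected in this assay, larger than the scatter. The expected step is an 8.3-fold higher number from compound 3 to compound 4 (0.92 log units; beyond the scatter). Compound 4 is therefore estimated at 2000 nM, in a range from 500 nM to 10000 nM.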

Compound 4, half-maximal inhibitory concentration: 3700 nM
Beside the measured number, compound 4's estimate is 1.9-fold (0.27 log units) below it; the range from low to high includes it.
By their numbers in this assay, from the lowest: compound 3; then compound 4; then compounds 1 and 2 (each within the scatter of the next).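

In this assay the group on a carbon with a double bond to nitrogen proves to matter, and pyridin-3-yl in place of 4-chlorophenyl gives a 15-fold higher number from compound 3 to compound 4 (1.19 log units; beyond the scatter) toward a weaker inhibitor. The earlier compounds shown here offered no reading of a change at this place alone. Nothing at hand accounts for the size of this step. Which part of the change carries the step stays open: the chlorine leaves and a ring nitrogen enters together. Also open, from the compounds shown here alone, is how a plain phenyl, or a methoxy group in place of the chlorine, would compare at this place.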